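This account rests on a few compounds, and the source may have more. Where it says the series, first, only, none or still open, it means among the compounds named here.

Compound 1 `CC1=NC(C)=C([N+](=O)[O-])C(c2ccccn2)/C1=C(\O)OC1CCCC1` is tested in a functional assay (cardiac atrium) for agonist activity, with Cavia porcellus as the target (a higher number here means that more compound is needed for the effect, a lower number that less compound is needed), where compound 1 gives 19800 nM. Compound 2 `CC1=NC(C)=C([N+](=O)[O-])C(c2ccccn2)/C1=C(\O)OCC(C)C` carries isobutyl in place of cyclopentyl on an oxygen on an unsaturated carbon and in this assay compound 2 gives 9100 nM, a change of a 2.2-fold lower number from compound 1 to compound 2 (0.34 log units; beyond the scatter). Compound 3 `CC1=NC(C)=C([N+](=O)[O-])C(c2cccnc2)/C1=C(\O)OC1CCCC1` differs from compound 1 by pyridin-3-yl in place of pyridin-2-yl on a saturated ring carbon, and in this assay compound 3 gives 3280 nM, a change of a 6.0-fold lower number from compound 1 to compound 3 (0.78 log units; beyond the scatter). Compound 4 `CC1=NC(C)=C([N+](=O)[O-])C(c2cccnc2)/C1=C(\O)OCC(C)C` has not yet been tested. Against compound 3 it carries isobutyl in place of cyclopentyl on an oxygen on an unsaturated carbon, the same change as that from compound 1 to compound 2, made on the core of compound 3. If that earlier step carries over, compound 4 is expected to show a step of a 2.2-fold lower number from compound 3 to compound 4 (0.34 log units; beyond the scatter) in this assay, resting on compound 3 at 3280 nM and on the measured step of a 2.2-fold lower number from compound 1 to compound 2 (0.34 log units; beyond the scatter). The value expected for compound 4 is thus 1500 nM, estimated to fall between 600 nM and 4000 nM.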

Compound 4, half-maximal effective concentration: 1740 nM
Compound 4: middle estimate off by 1.2-fold (0.06 log units), on the low side; the measured number falls inside the stated range.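

In this assay, isobutyl in place of cyclopentyl gives a 1.9-fold lower number from compound 3 to compound 4 (0.28 log units; within the scatter), which agrees with the same change on the other core: the same change on two cores in this assay, a 2.2-fold lower number (0.34 log units; beyond the scatter) from compound 1 to compound 2 and a 1.9-fold lower number (0.28 log units; within the scatter) from compound 3 to compound 4, 1.2-fold (0.06 log units) apart, within the scatter of two such steps. Pyridin-3-yl in place of pyridin-2-yl gives a 5.2-fold lower number from compound 2 to compound 4 (0.72 log units; beyond the scatter), which also agrees with its earlier step: the same change on two cores in this assay, a 6.0-fold lower number (0.78 log units; beyond the scatter) from compound 1 to compound 3 and a 5.2-fold lower number (0.72 log units; beyond the scatter) from compound 2 to compound 4, 1.2-fold (0.06 log units) apart, within the scatter of two such steps. Each change therefore carried over between the two cores shown, but these four compounds do not show that it would carry over to other cores, and they do not explain why the steps agree.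

From the compounds shown here alone, whether the same agreement holds with a longer chain on the oxygen remains open. The same question stands for a phenyl group in place of the pyridine groups.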